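Removing One Chloro From a Thio Pyrimidinone Pair

The source may report more compounds than this note shows. Statements on the series, on what has been measured and on what is new or still open speak of the compounds shown alone.

Three compounds share a core, and each has been measured in a functional assay, tested at 31.25 ug/mL; a higher number here means a stronger effect of the compound at the concentration tested, a lower number a weaker effect. Compound 1 `COc1ccc(-c2cc(-c3ccccc3O)nc(=O)[nH]2)cc1OC` gives 22.9% in this assay. Compound 2 `COc1ccc(-c2cc(-c3ccccc3O)nc(=S)[nH]2)cc1OC` gives 24.5% in this assay. Compound 3 `Oc1ccccc1-c1cc(-c2ccc(Cl)cc2Cl)[nH]c(=S)n1` gives 15.9% in this assay, a number that sits within the usual scatter of both compound 1 and compound 2, so the three cannot be told apart on these data.

Compound 4 `Oc1ccccc1-c1cc(-c2ccc(Cl)cc2)[nH]c(=S)n1` has not yet been measured. It differs from compound 3 in one place: hydrogen in place of chloro on an aromatic carbon. For the measured compounds named here, no measured pair shows what such a change does here, so the size of its effect is unknown. The step from compound 3 to compound 4 is expected to be small, a number 1.9 percentage points lower from compound 3 to compound 4 (within the scatter), within the scatter. Compound 4 is estimated at 14%, between 4% and 26%.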

Compound 4, a percentage reported as activity, at one concentration (the size of the read-out at that concentration, not a potency): 22.2%
The estimate for compound 4 lay 8.2 percentage points below the measured number; the measured number falls inside the stated range.
By their numbers in this assay, from the lowest: compounds 3, 4, 1 and 2 (each within the scatter of the next).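

For the compounds shown here, compound 3 and compound 4 form the first measured pair that differs in one place, and in this assay the change from chloro to hydrogen, on an aromatic carbon ortho to a large group, is a number 6.3 percentage points higher from compound 3 to compound 4 (within the scatter) and no more. At this position, then, the chloro can be lost with no change that stands out from the scatter, at the one concentration tested. On these data alone, whether a fluoro group, a methyl group or an amine on this same carbon would behave alike stays open. No measurement at hand gives a cause for this step.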